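Swapping the aryl group on a saturated ring carbon

The source may report more compounds than this note shows. Statements on the series, on what has been measured and on what is new or still open speak of the compounds shown alone.

Compound 1, with the structure `COc1cc(C2=NN(C(C)=O)C(c3c(Cl)cccc3Cl)O2)cc(OC)c1OC`, was tested in a functional assay on PC-3 cells (Homo sapiens) for antiproliferative activity, read by MTT assay, tested at 5 uM (a lower number here means a weaker effect, a higher number a stronger effect of the compound at the concentration tested), where compound 1 gives -2.2%. For the measured compounds named here, this is the lowest of the two numbers measured so far. The other measured compound, compound 2 with the structure `COc1cc(C(=O)N/N=C/c2ccccc2C(F)(F)F)cc(OC)c1OC`, is built on a different core, and in this assay compound 2 gives 52.9%, a number far above that of compound 1 and well beyond the usual scatter. Going by the values given here, no step between two measured compounds that differ in a single place has been measured here.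

Compound 3, with the structure `COc1ccc(C2OC(c3cc(OC)c(OC)c(OC)c3)=NN2C(C)=O)c(OC)c1`, has not yet been measured. It differs from compound 1 in one place: 2,4-dimethoxyphenyl in place of 2,6-dichlorophenyl on a saturated ring carbon. Because compound 1 sits at -2.2%, at the bottom of what has been seen, the step from compound 1 to compound 3 is expected to be small, either upward by a modest amount or none beyond the scatter, as a number 12.2 percentage points higher from compound 1 to compound 3 (beyond the scatter). The estimate for compound 3 in this assay is 10%, with a range from -10% to 35%.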

Compound 3, a percentage reported as inhibition, at one concentration (the size of the read-out at that concentration, not a potency): 92%
Estimate against measurement, compound 3: 82 percentage points below; measured number outside the range, above it.
By their numbers in this assay, from the lowest: compound 1; then compound 2; then compound 3.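

On the saturated ring carbon of the shared core, the aryl group turns out to matter a great deal: putting 2,4-dimethoxyphenyl in place of 2,6-dichlorophenyl produces a large change in the antiproliferative read-out (in this assay, a number 94.2 percentage points higher from compound 1 to compound 3 (beyond the scatter)). The core of compound 1 therefore cannot be written off on the result for compound 1 alone, since compound 3 keeps that same core and differs only in this one group. The swap changes the kind of substituent and the numbers in the group's name at the same time, so this single step cannot show whether the methoxy groups, the loss of the chlorine atoms or their arrangement on the phenyl ring accounts for it, and nothing available here explains the step.

From the compounds shown here alone, it remains open whether a phenyl ring carrying a single methoxy group, or one carrying an amine or a carboxylic acid, would give a number near that of compound 1 or near that of compound 3. Also open, going by these compounds, is how a longer chain in place of the acetyl group would behave alongside the 2,4-dimethoxyphenyl group.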